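Pyridin-3-yl replacing cyclohexyl on the piperazine nitrogen

The compounds below may be only part of what the source reports. "The series", "measured", "known", "first", "only" and "open" are said of these compounds alone.

Measured compounds:
- compound 1, `CC#CC(CC(=O)O)c1ccc(OCc2ccc(C(=O)N3CCN(c4ccccc4)CC3)s2)cc1`: 72 nM
- compound 2, `CC#CC(CC(=O)O)c1ccc(OCc2ccc(C(=O)N3CCN(C4CCCCC4)CC3)s2)cc1`: 820 nM

Of the compounds shown here, two have been measured in a functional assay on HEK293 cells for agonist activity at Free fatty acid receptor 1 (Homo sapiens), read by fluorescence and calcium flux; on this read-out lower numbers stand for an effect already at smaller amounts and higher numbers for an effect only at larger amounts of compound. Compound 2 stands at the highest of the two numbers; its nearest neighbour is compound 1, separated by the step of an 11-fold higher number from compound 1 to compound 2 (1.06 log units; beyond the scatter), a large one. Compound 3, `CC#CC(CC(=O)O)c1ccc(OCc2ccc(C(=O)N3CCN(c4cccnc4)CC3)s2)cc1`, is not yet measured. It differs from compound 2 in one place: pyridin-3-yl in place of cyclohexyl on an amine nitrogen in a ring, that is, one six-membered aromatic ring with 1 hetero atom enters where one six-membered non-aromatic ring of carbon only leaves. For the measured compounds named here, the only step that bears on this change is the one from compound 1 to compound 2, which exchanged an aromatic ring on the same ring nitrogen for the cyclohexyl ring and raised the number strongly. Reversing that kind of exchange, compound 3 is therefore expected to show a step of a 6.8-fold lower number from compound 2 to compound 3 (0.83 log units; beyond the scatter) in this assay. The estimate for compound 3 is 120 nM, with a range from 40 nM to 400 nM.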

Compound 3, half-maximal effective concentration: 1140 nM
The estimate for compound 3 lay 9.5-fold (0.98 log units) below the measured number, and the stated range ends below it.
By their numbers in this assay, from the lowest: compound 1; then compounds 2 and 3 (each within the scatter of the next).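

In this assay an aromatic ring on this amine nitrogen proves not to be enough to preserve the low number of compound 1, since pyridin-3-yl in place of phenyl gives a 16-fold higher number from compound 1 to compound 3 (1.20 log units; beyond the scatter) and so a large loss from a change of one ring atom. Pyridin-3-yl in place of cyclohexyl gives a 1.4-fold higher number from compound 2 to compound 3 (0.14 log units; within the scatter) and thus leaves the two compounds indistinguishable, although one ring is aromatic and the other is not. Nothing measured here accounts for this result.

The compounds shown leave open whether the place of the ring nitrogen matters, which pyridin-2-yl or pyridin-4-yl would test. They also leave open whether a phenyl ring carrying a methoxy group or a chlorine atom would match compound 1 or move away from it.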